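A Chlorophenyl Analog Awaits Its Cytotoxicity Reading

The compounds below may be only part of what the source reports. "The series", "measured", "known", "first", "only" and "open" are said of these compounds alone.

Compound 1 `C=CCOc1cc(OC)c(C(=O)/C=C/c2ccc(C)cc2)c(OCC=C)c1` was examined in an ADME assay on Vero cells (Chlorocebus sabaeus) for cytotoxicity, read by MTT assay (on this read-out lower numbers stand for stronger inhibition and higher numbers for weaker inhibition), where compound 1 gave 211000 nM. Compound 2 `C=CCOc1cc(OC)c(C(=O)/C=C/c2ccc[nH]2)c(OCC=C)c1` was also entered in this assay, where compound 2 is recorded as "not determined" (no result reported), so compound 2 stands without a number on this read-out. Compound 3 `C=CCOc1cc(OC)c(C(=O)/C=C/c2ccc(Cl)cc2)c(OCC=C)c1` differs from compound 2 by 4-chlorophenyl in place of 1H-pyrrol-2-yl on a double-bonded chain carbon bound to a double-bonded chain carbon. Going by the values given here, with no measured step joining this pair, only an expectation can be given: in this assay any step from compound 2 to compound 3 is expected to stay within the usual scatter, in neither direction. Compound 3 is expected to give 150000 nM, with a range from 50000 nM to 400000 nM.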

Compound 3, half-maximal inhibitory concentration: 10400 nM
Compound 3: the middle estimate sits 14-fold (1.16 log units) above what was measured, and the stated range ends above it.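

In this assay, the aromatic carbon that carries methyl in compound 1 proves sensitive: chloro in its place gives a 20-fold lower number from compound 1 to compound 3 (1.31 log units; beyond the scatter) and so stronger inhibition on this read-out. Going by these compounds alone, this is the first measured step, and it shows that a change of one group on that carbon can move the result well beyond the scatter. Nothing at hand accounts for the size of this step.

Going by these compounds, whether a bromo, methoxy or amine group on that carbon would lower the number further or raise it remains open. The step between compound 2 and compound 3 cannot be read, since compound 2 has no number.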